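Solubility of a triazolylmethylamine analogue in the pyrazolopyrimidine series

This account rests on a few compounds, and the source may have more. Where it says the series, first, only, none or still open, it means among the compounds named here.

Compounds measured so far:
compound 1 `Cc1cc(NCc2nccn2C)n2nc(C)c(-c3ccccc3)c2n1`, 26900 nM
compound 2 `Cc1cc(NCc2nccs2)n2nc(C)c(-c3ccccc3)c2n1`, 108000 nM
compound 3 `Cc1cc(NCC2CCCCN2)n2nc(C)c(-c3ccccc3)c2n1`, 189000 nM

In a physicochemical assay for solubility, read by HPLC, using the shake flask method, measured as kinetic solubility, with a stated time of 2 h, at pH 7.4 (on this read-out lower numbers stand for lower solubility and higher numbers for higher solubility), compound 3 gives the highest of the three numbers; compound 2 sits nearest, with the two values within the scatter, while compound 1 lies furthest, as seen in a 7.0-fold higher number from compound 1 to compound 3 (0.85 log units; beyond the scatter). The unmeasured compound 4 `Cc1cc(NCc2ncnn2C)n2nc(C)c(-c3ccccc3)c2n1` differs from compound 3 by 1-methyl-1H-1,2,4-triazol-5-yl in place of piperidin-2-yl on a saturated chain carbon bound to a nitrogen on an aromatic ring. The step that bears most on this is the one in which a five-membered aromatic ring bearing a methyl on nitrogen was replaced by the piperidine, a 7.0-fold higher number from compound 1 to compound 3 (0.85 log units; beyond the scatter); the present change runs the other way, back to a five-membered aromatic ring with a methyl on nitrogen. The step of a 1.8-fold higher number from compound 2 to compound 3 (0.24 log units; within the scatter), an aromatic ring without such a methyl, was smaller. Compound 4 is therefore expected to show a modest fall in this assay, a 4.7-fold lower number from compound 3 to compound 4 (0.67 log units; beyond the scatter). The estimate for compound 4 is 40000 nM, with a range from 12000 nM to 130000 nM.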

Compound 4, solubility: 185000 nM
The estimate for compound 4 lay 4.6-fold (0.67 log units) below the measured number; the measured number lies above the stated range.
By their numbers in this assay, from the lowest: compound 1; then compounds 2, 4 and 3 (each within the scatter of the next).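

In this assay, 1-methyl-1H-1,2,4-triazol-5-yl in place of piperidin-2-yl on a saturated chain carbon bound to a nitrogen on an aromatic ring gives a 1.0-fold lower number from compound 3 to compound 4 (0.01 log units; within the scatter) and so leaves the read-out unchanged within the scatter, despite the swap of a six-membered non-aromatic ring for a five-membered aromatic one. The two rings with a methyl on nitrogen do not read alike, with a 6.9-fold higher number from compound 1 to compound 4 (0.84 log units; beyond the scatter) on exchanging 1-methyl-1H-imidazol-2-yl for the triazole, whereas exchanging 1,3-thiazol-2-yl for it gives only a 1.7-fold higher number from compound 2 to compound 4 (0.23 log units; within the scatter), so a methyl on such a ring does not by itself go with the low number, and compound 1 alone stands apart from the other three. Nothing available accounts for this separation.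

On these data alone, whether a carboxylic acid, an open-chain amine or a longer chain at this place would read with compound 1 or with the other three remains open. Also open, as far as these compounds go, is whether the gap seen for 1-methyl-1H-imidazol-2-yl would persist on a core other than the shared one.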